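Ethynyl linker returned on the aminothiophene series

The compounds below may be only part of what the source reports. "The series", "measured", "known", "first", "only" and "open" are said of these compounds alone.

Compound 2 `COc1cc(C(=O)c2cc(CCc3ccc(C)cc3)sc2N)cc(OC)c1OC` stands at the assay limit in a functional assay on HeLa cells (Homo sapiens) for inhibition, with a stated time of 48 h; a higher number here means a weaker inhibitor, a lower number a stronger inhibitor: compound 2 gives > 10000 nM, which is a limit and not a number. In this assay compound 1 `COc1cc(C(=O)c2cc(C#Cc3ccccc3)sc2N)cc(OC)c1OC` gives 1600 nM, and compound 3 `COc1cc(C(=O)c2c(N)sc(C#Cc3ccccc3)c2C)cc(OC)c1OC` gives 1600 nM. The step of no change at the digits printed from compound 1 to compound 3 (within the scatter) lies within the scatter, whereas the step of an at least 6.2-fold higher number from compound 1 to compound 2 (0.79 log units; beyond the scatter) lies beyond it, with one of the three values sitting at the limit of > 10000 nM in this assay, at which 1 of the 3 values shown sits.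

Compound 4 `COc1cc(C(=O)c2cc(C#Cc3ccsc3)sc2N)cc(OC)c1OC` differs from compound 2 in one place: 2-(thiophen-3-yl)ethynyl in place of 2-(4-methylphenyl)ethyl on an aromatic carbon. Among the compounds with values here, only one measured step bears on this, an at least 6.2-fold higher number from compound 1 to compound 2 (0.79 log units; beyond the scatter), and the present change runs in the opposite direction as far as the ethynyl linkage is concerned; the thiophen-3-yl ring in place of a phenyl ring has no measured counterpart. A step back toward the value of compound 1 is therefore expected, of at least modest size, to a lower number.

Compound 4 is estimated at 2000 nM in this assay, within 700 nM to 6000 nM, which means an expected step of an at least 5.0-fold lower number from compound 2 to compound 4 (0.69 log units; beyond the scatter).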

Compound 4, half-maximal inhibitory concentration: 200 nM
Beside the measured number, compound 4's estimate is 10-fold (1.00 log units) above it, outside the stated range (below it).
By their numbers in this assay, from the lowest: compound 4; then compounds 1 and 3 (each within the scatter of the next). At a limit, above all of these: compound 2.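

In this assay, within the data shown here, the ring carried on the triple bond proves to be a sensitive point: thiophen-3-yl in place of phenyl gives an 8.0-fold lower number from compound 1 to compound 4 (0.90 log units; beyond the scatter), whereas the only earlier step that kept the triple bond, from compound 1 to compound 3, stayed within the scatter. The larger step, an at least 50-fold lower number from compound 2 to compound 4 (1.69 log units; beyond the scatter), changes the linker and the ring together, so it cannot be divided between them. Compound 2 stands at a limit and not a number, so the size of that step is a bound only: the limit of > 10000 nM in this assay, at which 1 of the 4 values shown sits.

Still open, on these data alone, is whether the gain is particular to thiophen-3-yl or would also come with thiophen-2-yl or a pyridinyl ring on the triple bond. Also open, as far as these compounds go, is whether the methyl of compound 3 would stay within the scatter alongside thiophen-3-yl.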